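The compounds below may be only part of what the source reports. "The series", "measured", "known", "first", "only" and "open" are said of these compounds alone.

Measured compounds:
compound 1, `Cc1ccc(O)c(C(=O)/C=C/c2cn(-c3ccc(F)cc3)nc2-c2sc(C)nc2C)c1` — in an ADME assay on HeLa cells (Homo sapiens) for inhibition, read by MTT assay (a lower number here means a stronger inhibitor of growth, a higher number a weaker inhibitor of growth), compound 1 gives 29.9 ug/mL
compound 2, `Cc1nc(C)c(-c2nn(-c3ccc(F)cc3)cc2/C=C/C(=O)c2cc(Cl)c(C)cc2O)s1` — in this assay compound 2 gives 34.9 ug/mL
compound 3, `Cc1nc(C)c(-c2nn(-c3ccc(F)cc3)cc2C2CC(c3cc(Br)ccc3O)=NN2)s1` — in this assay compound 3 gives 21.6 ug/mL

Among the three numbers shown, compound 3 holds the lowest, though its gaps to compound 1 and to compound 2 both lie within the scatter. Compound 4, `Cc1nc(C)c(-c2nn(-c3ccc(F)cc3)cc2C2CC(c3c(O)cc(C)c(Cl)c3C)=NN2)s1`, differs from compound 3 by 3-chloro-6-hydroxy-2,4-dimethylphenyl in place of 5-bromo-2-hydroxyphenyl on a carbon with a double bond to nitrogen. Among the measured compounds shown here, the one measured step, a 1.2-fold higher number from compound 1 to compound 2 (0.07 log units; within the scatter), exchanged one hydroxyphenyl group for another on a carbonyl carbon and stayed within the scatter; it bears only loosely on the present change, which sits on a different part of the structure. The expectation is a small step, a 1.2-fold higher number from compound 3 to compound 4 (0.06 log units; within the scatter), with compound 4 estimated at 25 ug/mL, in a range from 12 ug/mL to 50 ug/mL.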

Compound 4, concentration for 50% growth inhibition: 25.2 ug/mL
The estimate for compound 4 lay 1.0-fold (0.00 log units) below the measured number; low and high end bracket the measured number.
By their numbers in this assay, from the lowest: compounds 3, 4, 1 and 2 (each within the scatter of the next).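

In this assay, among the compounds shown here, the exchange of 5-bromo-2-hydroxyphenyl for 3-chloro-6-hydroxy-2,4-dimethylphenyl gave a 1.2-fold higher number from compound 3 to compound 4 (0.07 log units; within the scatter) and thus offers the first step at this position, on the carbon with a double bond to nitrogen. Here, a larger group with chlorine in place of bromine and two added methyl groups left the number within the scatter. Nothing at hand explains this result. The compounds shown leave open whether a phenyl group without its hydroxyl would keep the number within the scatter. They also leave open how an amine or a carboxylic acid on this ring would read.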